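The source may hold more compounds than are shown below. What is called first, only, known or untested is meant among the compounds shown, and "the series" means these compounds.

Of the compounds shown here, two built on the same core have been measured so far, and a third awaits measurement. Compound 1 `COc1ccccc1C(=O)NCc1ccc(CNS(=O)(=O)c2ccccc2)cc1` carries a 2-methoxyphenyl on its carbonyl carbon; in an assay on MDA-MB-231 cells for binding affinity to C-X-C chemokine receptor type 4 (Homo sapiens), read by immunofluorescence and microscopy, with stated times of 10 min and 30 min (a lower number here means that less compound is needed, a higher number that more compound is needed for the effect), compound 1 gives 1 nM. Compound 2 `O=C(NCc1ccc(CNS(=O)(=O)c2ccccc2)cc1)c1ccncc1` carries a pyridin-4-yl at that same place, and in this assay compound 2 gives 10 nM. Among the compounds with values here, of these two numbers, compound 2 stands at the higher one, the single step being a 10-fold higher number from compound 1 to compound 2 (1.00 log units; beyond the scatter).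

Compound 3 `COc1cccc(C(=O)NCc2ccc(CNS(=O)(=O)c3ccccc3)cc2)c1` is the unmeasured compound. It differs from compound 2 in one place: 3-methoxyphenyl in place of pyridin-4-yl on a carbonyl carbon. Within the data shown here, only the step from compound 1 to compound 2 bears on this change, and it does so in reverse: swapping a methoxyphenyl for the pyridin-4-yl raised the number well beyond the scatter, so putting a methoxyphenyl back in its place is expected to lower it again. Since the methoxy in compound 3 sits on the 3-position rather than the 2-position of compound 1, a full return to the number of compound 1 is not assured. The expected step is therefore a 3.3-fold lower number from compound 2 to compound 3 (0.52 log units; beyond the scatter) in this assay, and compound 3 is estimated at 3 nM, within a range from 1 nM to 10 nM.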

Compound 3, effective concentration (reported as EC, without a stated level of effect): > 1000 nM
Compound 3: only a limit was reported; the forecaster's own chance of this, stated with the estimate: 5%; middle value at least 330-fold (2.52 log units) from the limit.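

This result shows that the carbonyl carbon's substituent is far more sensitive than the first two compounds suggested: in this assay, the 3-methoxyphenyl brings an at least 100-fold higher number from compound 2 to compound 3 (2.00 log units; beyond the scatter), so carrying a methoxyphenyl here does not by itself give a low number. Moving from the 2-methoxyphenyl to the 3-methoxyphenyl brings an at least 1000-fold higher number from compound 1 to compound 3 (3.00 log units; beyond the scatter), which means that the two methoxyphenyl groups cannot be treated as interchangeable, and compound 2, with its pyridin-4-yl, falls between them. The true size of both steps remains unknown, since the reading for compound 3 is a limit and not a number: the limit of > 1000 nM in this assay, at which 1 of the 3 values shown sits.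

The compounds shown do not tell how a plain phenyl, an aminophenyl or a carboxyphenyl would read at this carbonyl carbon, so it remains unclear whether the methoxy group helps in one placement or hurts in the other. All three compounds also share the same core, which leaves open whether this sharp difference between the two methoxyphenyl groups would persist if another part of the molecule were changed.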